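Bromo for trifluoromethyl on the benzyl ring

The source may report more compounds than this note shows. Statements on the series, on what has been measured and on what is new or still open speak of the compounds shown alone.

Compound 1 `O=S(=O)(NCCCNCc1ccccc1Cl)c1cc(C(F)(F)F)cc(C(F)(F)F)c1`: 8800 nM
Compound 2 `O=S(=O)(NCCCCNCc1ccc(Br)cc1)c1cc(C(F)(F)F)cc(C(F)(F)F)c1`: 1500 nM
Compound 3 `O=S(=O)(NCCCNCc1ccc(C(F)(F)F)cc1)c1cc(C(F)(F)F)cc(C(F)(F)F)c1`: 1400 nM

Three sulfonamides sharing one core were tested in a functional assay on MCF7 cells (Homo sapiens) for inhibition, read by MTT assay, with a stated time of 72 h; a higher number here means a weaker inhibitor of growth, a lower number a stronger inhibitor of growth. Compound 3 has the lowest number of the three; its nearest neighbour is compound 2, whose value lies within the scatter of it, while compound 1 stands well apart.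

Compound 4 `O=S(=O)(NCCCNCc1ccc(Br)cc1)c1cc(C(F)(F)F)cc(C(F)(F)F)c1` is unmeasured. It differs from compound 3 by bromo in place of trifluoromethyl on an aromatic carbon.

Among the measured compounds shown here, no measured step makes exactly this exchange. For the measured compounds named here, two steps bear on it indirectly: a 5.9-fold lower number from compound 1 to compound 2 (0.77 log units; beyond the scatter) and a 6.3-fold lower number from compound 1 to compound 3 (0.80 log units; beyond the scatter). Both move from the same starting point to a benzyl ring carrying a para substituent, one bromo and one trifluoromethyl, and they land within the scatter of each other, although compound 2 also carries a longer chain than compound 3. Taken together, compound 2 and compound 3 give no sign that bromo and trifluoromethyl in this position separate from each other in this assay.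

Compound 4 is therefore expected to show a 1.1-fold higher number from compound 3 to compound 4 (0.03 log units; within the scatter), a step inside the scatter, with an estimated value of 1500 nM and a likely range from 600 nM to 4000 nM.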

Compound 4, concentration for 50% growth inhibition: 1900 nM
The estimate for compound 4 lay 1.3-fold (0.10 log units) below the measured number; low and high end bracket the measured number.
By their numbers in this assay, from the lowest: compounds 3, 2 and 4 (each within the scatter of the next); then compound 1.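

Read directly on one chain, the exchange gives a 1.4-fold higher number from compound 3 to compound 4 (0.13 log units; within the scatter) in this assay, so bromo and trifluoromethyl do not separate at this place on the benzyl ring, as the indirect comparison of compound 2 and compound 3 could only suggest. The chain can now be read apart from the ring substituent: with 4-bromobenzyl held constant, the result is a 1.3-fold higher number from compound 2 to compound 4 (0.10 log units; within the scatter), so the longer chain of compound 2 shows no difference from the chain of compound 4 in this assay. On the chain shared by compound 1, compound 3 and compound 4, the result a 4.6-fold lower number from compound 1 to compound 4 (0.67 log units; beyond the scatter) stands beside a 6.3-fold lower number from compound 1 to compound 3 (0.80 log units; beyond the scatter), so both 4-substituted benzyl compounds lie apart from the 2-chlorobenzyl compound, although the step to compound 4 changes both the halogen and its place on the ring.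

The compounds shown offer no measured basis for explaining any of these steps. They also leave open whether chloro at the 4-position, or a nitrile or a methoxy group there, would stay with bromo and trifluoromethyl, and whether a shorter chain or a still longer chain would remain as close as the two chains seen here.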